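Ethyl to Isopropyl on the Shared Core: Clearance Expectation

A few compounds are considered here, and "the series" means these few. Any claim that something is new, unique, unknown or untested is made for them only; others in the source may bear on it.

Of the compounds shown here, three sharing one core have been measured in an ADME assay on microsomes from liver (Homo sapiens) for metabolic stability; on this read-out lower numbers stand for slow clearance and higher numbers for fast clearance. Compound 1 `CCn1cnc2c(-c3ccc(F)c(-c4cccnc4)c3)cnnc21` gives 78 mL.min-1.g-1; compound 2 `CCn1cnc2c(-c3ccc(F)c(Oc4cnc(C#N)nc4)c3)cnnc21` gives 49 mL.min-1.g-1; compound 3 `CCn1cnc2c(-c3ccc(F)c(-c4ccnc(C)c4)c3)cnnc21` gives 157 mL.min-1.g-1. Compound 3 stands highest of the three numbers, but its step from compound 1 is a 2.0-fold higher number from compound 1 to compound 3 (0.30 log units; within the scatter), while the step from compound 2 is a 3.2-fold higher number from compound 2 to compound 3 (0.51 log units; beyond the scatter). The remaining step, a 1.6-fold lower number from compound 1 to compound 2 (0.20 log units; within the scatter), also lies within the scatter. All three of these steps change the aromatic ring attached to the fluorinated phenyl ring.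

Compound 4 `Cc1cc(-c2cc(-c3cnnc4c3ncn4C(C)C)ccc2F)ccn1` differs from compound 3 elsewhere: methyl in place of hydrogen on a saturated chain carbon bound to an aromatic nitrogen and a saturated chain carbon In words of the difference cut one bond further out, ethyl becomes isopropyl. Going by the values given here, none of the measured steps touches this saturated chain, so no step among the measured compounds bears directly on it. In the absence of such a precedent, the expected step from compound 3 to compound 4 is a 1.0-fold lower number from compound 3 to compound 4 (0.02 log units; within the scatter), that is, none beyond the usual scatter in this assay. Compound 4 is therefore estimated at 150 mL.min-1.g-1 in this assay, with a range from 70 mL.min-1.g-1 to 320 mL.min-1.g-1.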

Compound 4, intrinsic clearance in microsomes: 102 mL.min-1.g-1
Compound 4: the middle estimate sits 1.5-fold (0.17 log units) above what was measured, and the stated range covers the measured number.
By their numbers in this assay, from the lowest: compounds 2, 1, 4 and 3 (each within the scatter of the next, the first and the last beyond it).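

In this assay, the step at this saturated chain carbon, where ethyl becomes isopropyl, reads a 1.5-fold lower number from compound 3 to compound 4 (0.19 log units; within the scatter) and so stays inside the usual scatter. Going by these compounds alone, this is the first reading at this position, since the earlier steps all changed the aromatic group elsewhere in the molecule, and it shows that with the 2-methylpyridin-4-yl group of compound 3 in place, one added methyl leaves the clearance number indistinguishable from that of the ethyl parent. No measurement is available that would explain this step or tie it to any property of the added methyl.

The compounds shown leave open whether the same ethyl to isopropyl change would also stay within the scatter on compound 1 or compound 2, as this single pair speaks only for the 2-methylpyridin-4-yl series. They also leave open how the read-out would respond at this position to a larger or differently built group, such as a tert-butyl, a cyclopropyl, a longer chain or a chain ending in an amine.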